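Amide partner variation on a shared core: toward compound 3

A few compounds are considered here, and "the series" means these few. Any claim that something is new, unique, unknown or untested is made for them only; others in the source may bear on it.

Measured so far in an assay on isolated protein for inhibition of Rho-associated protein kinase 1 (Homo sapiens), read by scintillation counting, radiometric assay and 33P incorporation, with a stated time of 40 min, in the presence of a further agent that is not named here; a higher number here means a weaker inhibitor, a lower number a stronger inhibitor:
compound 1, `CCOc1ccc(C(=O)Nc2cccc(NC(=O)COc3ccc4c(=O)ccoc4c3)c2)cc1`: 17 nM
compound 2, `O=C(COc1ccc2c(=O)ccoc2c1)Nc1cccc(NS(=O)(=O)c2ccc(OC(F)(F)F)cc2)c1`: 6440 nM

Compound 1 holds the lowest of the two numbers in this assay. The nearest, compound 2, gives a far higher value, a gap well beyond the usual scatter of repeated measurements. Among the measured compounds shown here, the two compounds differ in more than one place, so no single-change step between them is available; their two values are all that can be said of the pair.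

Compound 3, `Nc1cccc(C(=O)Nc2cccc(NC(=O)COc3ccc4c(=O)ccoc4c3)c2)c1`, has not yet been measured in this assay. Against compound 1 the change is 3-aminophenyl in place of 4-ethoxyphenyl on a carbonyl carbon. The new group keeps the amide-type linkage of compound 1 intact and alters only the aromatic partner on the carbonyl carbon.

For the measured compounds named here, no measured single-change step exists to anchor the expectation, so it rests on compound 1 alone at 17 nM. The step from compound 1 to compound 3 is expected to be small, toward a somewhat higher number, likely near the edge of the scatter: a 2.4-fold higher number from compound 1 to compound 3 (0.37 log units; beyond the scatter). Compound 3 is accordingly estimated at 40 nM, with a range from 8 nM to 200 nM.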

Compound 3, half-maximal inhibitory concentration: 670 nM
Compound 3: middle estimate off by 17-fold (1.22 log units), on the low side; measured number above the stated range.
By their numbers in this assay, from the lowest: compound 1; then compound 3; then compound 2.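

In this assay the exchange of 4-ethoxyphenyl for 3-aminophenyl on a carbonyl carbon gives a 39-fold higher number from compound 1 to compound 3 (1.60 log units; beyond the scatter) while the amide-type linkage and the shared core stay unchanged. The aromatic partner on this carbonyl carbon is therefore a place where one change can move the number by a large step, well beyond the usual scatter of repeated measurements, which the earlier pair could not show because compound 1 and compound 2 differ in more than one place. The data on hand offer no measured property or other finding that accounts for the size of this step.

The change is not a single feature: 4-ethoxyphenyl and 3-aminophenyl differ in the substituent, in the number in the group's name and in hydrogen-bond donors, and this one step cannot separate these differences. Unsubstituted phenyl on the same carbonyl carbon, together with partners such as 4-aminophenyl, 3-ethoxyphenyl or a ring bearing a longer alkoxy chain, would be needed to tell which of them goes with the higher number.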